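Replacing the 6-chloropyridin-2-yl group: working notes

A few compounds are considered here, and "the series" means these few. Any claim that something is new, unique, unknown or untested is made for them only; others in the source may bear on it.

Measured in a functional assay (blood) for inhibition, with Homo sapiens as the target; a higher number here means a weaker inhibitor, a lower number a stronger inhibitor:
- compound 1 `CC(C)(C)Sc1c(CC(C)(C)C(=O)O)n(Cc2ccc(Cl)cc2)c2ccc(OCc3ccc4cnccc4n3)cc12`: 980 nM
- compound 2 `CC(C)(C)Sc1c(CC(C)(C)C(=O)O)n(Cc2ccc(Cl)cc2)c2ccc(OCc3cccc(Cl)n3)cc12`: 410 nM

Of the two measured compounds, compound 2 has the lower number, at 410 nM, and so is the stronger inhibitor in this assay. Compound 3 `CC(COc1ccc2c(c1)c(SC(C)(C)C)c(CC(C)(C)C(=O)O)n2Cc1ccc(Cl)cc1)c1ccccn1` is still unmeasured. It differs from compound 2 by 1-(pyridin-2-yl)ethyl in place of 6-chloropyridin-2-yl on a saturated chain carbon bound to an oxygen on an aromatic ring, with 1-(pyridin-2-yl)ethyl in place of 6-chloropyridin-2-yl on a saturated chain carbon bound to an oxygen on an aromatic ring.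

For the measured compounds named here, only one measured step bears on this change: a 2.4-fold lower number from compound 1 to compound 2 (0.38 log units; beyond the scatter). It is modest, though beyond the scatter, and it involves a change of group at the same place. Going by the values given here, no measured compound carries the 1-(pyridin-2-yl)ethyl group, so the direction is poorly constrained. A small rise in the number is expected, of no more than similar size and possibly within the scatter, as compound 2 sits at the low end of just two values. The expected step is a 1.3-fold higher number from compound 2 to compound 3 (0.10 log units; within the scatter). The estimate for compound 3 is 520 nM, with an expected range of 170 nM to 1500 nM.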

Compound 3, half-maximal inhibitory concentration: 270 nM
Compound 3: middle estimate off by 1.9-fold (0.28 log units), on the high side, within the range that was stated.
By their numbers in this assay, from the lowest: compounds 3 and 2 (each within the scatter of the next); then compound 1.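

In this assay, the swap of 6-chloropyridin-2-yl for 1-(pyridin-2-yl)ethyl gives a 1.5-fold lower number from compound 2 to compound 3 (0.18 log units; within the scatter), so at this place, on a saturated chain carbon bound to an oxygen on an aromatic ring, a group without chlorine and with an added ethyl chain reads level with the chlorinated one. For the compounds shown here, this is the first view of a second group with one six-membered aromatic ring here, and against the larger group of compound 1 it gives a 3.6-fold lower number from compound 1 to compound 3 (0.56 log units; beyond the scatter), so both groups with one such ring, in compound 2 and compound 3, lie beyond the scatter from the group with two rings, with no compound of the three going against this. No measurement to hand accounts for any of these differences.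

Compound 3 differs from compound 2 both in the loss of chlorine and in the ethyl chain, so the two changes cannot be told apart, and a plain pyridin-2-yl group would be needed to separate them. Also open, from the compounds shown here alone, is how a longer chain, or an amine or a carboxylic acid on the pyridine ring, would read in this assay at this place.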